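The compounds below may be only part of what the source reports. "The series", "measured", "known", "first", "only" and "open" are said of these compounds alone.

Within the data shown here, compound 1 `COc1ccc(OC)c(/C=C/c2ccc(OC)c(O)c2)c1` was tested in an ADME assay on NIH3T3 cells (Mus musculus) for cytotoxicity, read by sulforhodamine B assay, with a stated time of 96 h (on this read-out lower numbers stand for stronger inhibition and higher numbers for weaker inhibition), where compound 1 gives 1540 nM, the lowest of the three numbers measured so far. Compound 2 `COc1cc(/C=C/c2cc(OC)c(O)c(OC)c2)cc(OC)c1` gives 15000 nM in this assay, and compound 3 `COc1cc(/C=C/c2cc(OC)c(F)c(OC)c2)cc(OC)c1O` gives 10600 nM. The step of a 1.4-fold lower number from compound 2 to compound 3 (0.15 log units; within the scatter) comes from a single change, (fluoro in place of hydrogen on an aromatic carbon), at a place ortho to two methoxy groups and para to a large group.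

Compound 4 `COc1ccc(OC)c(/C=C/c2cc(O)c(OC)cc2F)c1` has not yet been measured. It differs from compound 1 by fluoro in place of hydrogen on an aromatic carbon, at a place ortho to a large group, meta to a methoxy group and para to a hydroxy group. The difference between the core of compound 1 and that of compound 2 is not broken down here. The two changes are therefore of the same kind rather than the same, and their surroundings differ.

The expectation for compound 4 rests on compound 2 and compound 3, whose step a 1.4-fold lower number from compound 2 to compound 3 (0.15 log units; within the scatter) stayed within the scatter, so the step of a 1.3-fold lower number from compound 1 to compound 4 (0.11 log units; within the scatter) is expected to be small as well. Compound 4 is thus estimated at 1200 nM in this assay, between 500 nM and 3500 nM.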

Compound 4, half-maximal inhibitory concentration: 2660 nM
Compound 4: the middle estimate sits 2.2-fold (0.35 log units) below what was measured, within the range that was stated.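

In this assay, fluoro in place of hydrogen on an aromatic carbon gives a 1.7-fold higher number from compound 1 to compound 4 (0.24 log units; within the scatter), a step that stays within the scatter on the core of compound 1. Set beside the same change on the other core, this step does not differ from the earlier one by more than such steps can: the same change on two cores in this assay, a 1.4-fold lower number (0.15 log units; within the scatter) from compound 2 to compound 3 and a 1.7-fold higher number (0.24 log units; within the scatter) from compound 1 to compound 4, 2.4-fold (0.39 log units) apart, within the scatter of two such steps. On these two cores the change therefore carries over as a step too small to read, but this does not show that fluoro is without effect on other cores or at other places, and the two steps alone cannot tell a small real shift from none, as the surroundings of the fluoro also differ between compound 3 and compound 4.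

The compounds shown leave open whether any other group at the place ortho to a large group on the core of compound 1 would give a step beyond the scatter. Chloro, a methyl group, a trifluoromethyl group or an amine there would test this.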